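Swapping Chloro for Fluoro on a Dicyano Ring

This account rests on a few compounds, and the source may have more. Where it says the series, first, only, none or still open, it means among the compounds named here.

Of the compounds shown here, three have been measured in a functional assay on SK-OV-3 cells (Homo sapiens) for antiproliferative activity, read by MTT assay; on this read-out lower numbers stand for stronger inhibition and higher numbers for weaker inhibition. Compound 1 `N#Cc1c(F)c(Cl)c(C(C(=O)c2ccccc2)=C2NCCN2)c(C#N)c1F` gives 32.6 ug/mL. Compound 2 `N#Cc1c(F)c(F)c(C(C(=O)c2ccccc2)=C2NCCN2)c(C#N)c1F`, which carries the change (fluoro in place of chloro on an aromatic carbon), gives 30.3 ug/mL. The step of a 1.1-fold lower number from compound 1 to compound 2 (0.03 log units; within the scatter) is therefore too small to count as a real shift. Compound 3 `N#Cc1c(F)c(Cl)c(C(C(=O)c2ccc(F)cc2)=C2NCCCN2)c(C#N)c1F` gives 8.2 ug/mL, the lowest of the three numbers; its gaps to compound 1 and to compound 2 both lie beyond the usual scatter. How the core of compound 3 differs from the core of compound 1 is not broken down here.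

Compound 4 `N#Cc1c(F)c(F)c(C(C(=O)c2ccc(F)cc2)=C2NCCCN2)c(C#N)c1F` has not yet been measured. It is related to compound 3 by fluoro in place of chloro on an aromatic carbon, and the surroundings of this change, as described, are the same word for word as those of the change from compound 1 to compound 2, so it is the same change made on a different core. Since that earlier change moved the number only within the scatter, the same is expected here. The step of a 1.1-fold lower number from compound 3 to compound 4 (0.03 log units; within the scatter) is expected to be small, because the matching step a 1.1-fold lower number from compound 1 to compound 2 (0.03 log units; within the scatter) stayed within the scatter. Compound 4 is estimated to give 7.6 ug/mL in this assay, most likely between 3.6 ug/mL and 16 ug/mL. This rests on a single prior example of the change, so the range is kept wide.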

Compound 4, half-maximal inhibitory concentration: 0.5 ug/mL
Estimate against measurement, compound 4: 15-fold (1.18 log units) above; the measured number lies below the stated range.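

In this assay, fluoro in place of chloro on an aromatic carbon did not act alike on the two cores: the same change on two cores in this assay, a 1.1-fold lower number (0.03 log units; within the scatter) from compound 1 to compound 2 and a 16-fold lower number (1.21 log units; beyond the scatter) from compound 3 to compound 4, 15-fold (1.18 log units) apart, beyond the scatter of two such steps. On the second core the swap gives a 16-fold lower number from compound 3 to compound 4 (1.21 log units; beyond the scatter), a large step, so a swap that changed almost nothing on one core cannot be assumed to change almost nothing on another in this series. Among the compounds shown here, this does not show which difference between the two cores matters or why the swap counts on one and not the other, and with only two pairs it gives no rule for how the swap would behave on any further core.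

The compounds shown leave open whether the large step belongs to fluoro alone or whether other groups on that same aromatic carbon, such as bromo, methoxy or an amine, would also set the second core apart from the first. As far as these compounds go, it also remains open how the swap would behave on cores that carry only one of the differences between these two, which would be needed to tie the contrast to a single place in the structure.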